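Compound 1 and an untested sulfur-containing relative

The source may report more compounds than this note shows. Statements on the series, on what has been measured and on what is new or still open speak of the compounds shown alone.

Compound 1 `CC(C)[C@@H](c1ccc(-c2ccc3cccc(F)c3c2)[nH]c1=O)[C@@H]1OC(=O)NC1=O`: 3.15 10^-6 cm/s
Compound 2 `CC(C)C1(c2ccc(-c3ccc4ccccc4c3)[nH]c2=O)OC(=O)NC1=O`: "not determined" (no result reported)

Going by the values given here, in an ADME assay on MDCK cells (Canis lupus familiaris) for permeability, in the apical to basolateral direction (a higher number here means that the compound crosses the layer faster, a lower number that the compound crosses the layer more slowly), compound 1 gives 3.15 10^-6 cm/s, the only number available, so its rank among related compounds remains unknown. Compound 3 `CC(C)[C@H](C[C@H]1SC(=O)NC1=O)c1ccc(-c2ccc3cccc(F)c3c2)[nH]c1=O` has (2,4-dioxo-1,3-thiazolidin-5-yl)methyl in place of 2,4-dioxo-1,3-oxazolidin-5-yl on a saturated chain carbon bound to an aromatic carbon and a saturated chain carbon. Among the compounds with values here, no measured pair shows what such a swap does, so no change beyond the usual scatter is expected in this assay. The expected size of the change is a 1.1-fold higher number from compound 1 to compound 3 (0.05 log units; within the scatter). For compound 3 the estimated value is 3.5 10^-6 cm/s, with an expected range from 1.5 10^-6 cm/s to 8 10^-6 cm/s.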

Compound 3, apparent permeability: 17.6 10^-6 cm/s
For compound 3 the middle estimate is 5.0-fold (0.70 log units) below the measured one; measured number above the stated range.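

In this assay, going by these compounds alone, the swap on this saturated chain carbon gives a 5.6-fold higher number from compound 1 to compound 3 (0.75 log units; beyond the scatter), the first sign that a change of group here can move this number beyond the scatter. Leaving 2,4-dioxo-1,3-oxazolidin-5-yl for (2,4-dioxo-1,3-thiazolidin-5-yl)methyl brings in sulfur for one oxygen and one more carbon in a single step. No measurement shown gives a cause for the rise.

Which of these two differences carries the step stays open. So does what a carboxylic acid or an amine would do at this place.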